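Series notes: aryl variation and a second chloro

A few compounds are considered here, and "the series" means these few. Any claim that something is new, unique, unknown or untested is made for them only; others in the source may bear on it.

Compound 3 `CC(C)(C)Cc1c(-c2ccccc2)sc(N)c1C(=O)c1ccc(Cl)cc1` gives 1% in an assay on CHO cells for displacement of a labelled ligand from adenosine receptor A3 (Homo sapiens), read by scintillation counting, tested at 10 uM; a lower number here means less inhibition, a higher number more inhibition at the concentration tested (going by the name of the read-out). Compound 1 `CC(C)(C)Cc1c(-c2ccc(F)cc2F)sc(N)c1C(=O)c1ccc(Cl)cc1` gives 1% in this assay, and compound 2 `CC(C)(C)Cc1c(-c2ccc(Cl)cc2)sc(N)c1C(=O)c1ccc(Cl)cc1` gives 1%. The steps of no change at the digits printed from compound 1 to compound 2 (within the scatter), no change at the digits printed from compound 1 to compound 3 (within the scatter) and no change at the digits printed from compound 2 to compound 3 (within the scatter) are all within the scatter, so compound 3 stands level with compounds 1 and 2. Compound 4 `CC(C)(C)Cc1c(-c2ccccc2)sc(N)c1C(=O)c1ccc(Cl)cc1Cl` differs from compound 3 by chloro in place of hydrogen on an aromatic carbon. Among the compounds with values here, none of the measured steps touches that ring; each of them swaps phenyl, 4-chlorophenyl or 2,4-difluorophenyl on the shared core, so no step bears directly on this change. Since every measured compound sits at the same level, the expected step of a number 1 percentage points higher from compound 3 to compound 4 (within the scatter) is none beyond the scatter. Compound 4 is expected to give 2%, in the range -8% to 12%.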

Compound 4, a percentage reported as inhibition, at one concentration (the size of the read-out at that concentration, not a potency): 1%
Beside the measured number, compound 4's estimate is 1 percentage points above it, within the range that was stated.
By their numbers in this assay, from the lowest: compounds 1, 2, 3 and 4 (each within the scatter of the next).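

The 4-chlorophenyl to 2,4-dichlorophenyl change gives no change at the digits printed from compound 3 to compound 4 (within the scatter) in this assay. Within the data shown here, it is the first measured step on this ring, as the earlier steps changed only the other aryl group. A chloro on this carbon, ortho to a large group, therefore leaves compound 4 level with compound 3, and nothing available bears on why.

The compounds shown leave open whether an amine or a carboxylic acid on this carbon would move the read-out. Also open, going by these compounds, is whether a methoxy group elsewhere on this ring would do so.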